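Lengthening the Alkyl Chain of a Phosphodiester Dithiocarbamate

A few compounds are considered here, and "the series" means these few. Any claim that something is new, unique, unknown or untested is made for them only; others in the source may bear on it.

Of the compounds shown here, two have been measured in a functional assay on MCF7 cells (Homo sapiens) for inhibition, read by MTT assay, with stated times of 18 h and 4 h; on this read-out lower numbers stand for stronger inhibition and higher numbers for weaker inhibition. Compound 1, `CCCCCCCCCCCCCCCCOP(=O)(O)OCCSC(=S)N1CCCCC1`, gives 29000 nM. Compound 2, `CCCOP(=O)(O)OCCSC(=S)N1CCCC1`, gives 73000 nM, the highest of the two numbers and the weaker of the pair, with compound 1 beyond the scatter below it. The two compounds differ in more than one place, so no single change accounts for the gap.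

Compound 3, `CCCCCCCCCCOP(=O)(O)OCCSC(=S)N1CCCC1`, has not yet been measured. It differs from compound 2 in one place: heptyl in place of hydrogen on a saturated chain carbon, three bonds along the chain from an oxygen on an unsaturated carbon. Compound 1, the compound that carries the longer chain, gives 29000 nM, and on that basis compound 3 is expected to move toward compound 1, with an estimated step of a 2.1-fold lower number from compound 2 to compound 3 (0.32 log units; beyond the scatter) in this assay. Compound 3 is therefore estimated at 35000 nM, with a range of 15000 nM to 80000 nM.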

Compound 3, half-maximal inhibitory concentration: 70000 nM
Estimate against measurement, compound 3: 2.0-fold (0.30 log units) below, within the range that was stated.
By their numbers in this assay, from the lowest: compound 1; then compounds 3 and 2 (each within the scatter of the next).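

In this assay, heptyl in place of hydrogen on a saturated chain carbon, three bonds along the chain from an oxygen on an unsaturated carbon, gives a 1.0-fold lower number from compound 2 to compound 3 (0.02 log units; within the scatter) and so stays within the usual scatter. The earlier compounds shown here differ in more than one place and could not show this: taken alone, with the rest of compound 2 unchanged, this lengthening of the chain leaves the read-out where it was. Nothing measured here speaks to why the step is so small.

The compounds shown leave open whether a longer chain than that of compound 3, or an amine or a carboxylic acid at its end, would move the number on this core. They also leave open how much of the gap to compound 1 lies in the chain and how much in the other place where it differs.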